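The source may hold more compounds than are shown below. What is called first, only, known or untested is meant among the compounds shown, and "the series" means these compounds.

Measured in a functional assay on A375-C5 cells (Homo sapiens) for inhibition, read by sulforhodamine B assay, with a stated time of 48 h; on this read-out lower numbers stand for stronger inhibition of growth and higher numbers for weaker inhibition of growth:
compound 1 `COC(=O)c1sc2cc(C#Cc3ccc(N)cc3)cnc2c1N`: 4800 nM
compound 2 `COC(=O)c1sc2cc(C#Cc3cccnc3)cnc2c1N`: > 150000 nM
compound 3 `COC(=O)c1sc2cc(C#Cc3cccc(N)c3)cnc2c1N`: 11600 nM.

For compound 2 the value is a limit of this assay, not a number (the limit of > 150000 nM in this assay, at which 1 of the 3 values shown sits). Compound 1 holds the lowest of the two numbers, with compound 3 its nearest neighbour. The step to compound 4 `COC(=O)c1sc2cc(C#Cc3cccc(OC)c3)cnc2c1N` changes the group on the triple-bonded carbon: 3-methoxyphenyl in place of 4-aminophenyl on a triple-bonded carbon. Among the measured compounds shown here, two measured steps bear on it. Moving the amino group to the 3-position gave a 2.4-fold higher number from compound 1 to compound 3 (0.38 log units; beyond the scatter). Exchanging the carbon-only ring for pyridin-3-yl gave an at least 31-fold higher number from compound 1 to compound 2 (1.49 log units; beyond the scatter). Compound 4 keeps a carbon-only ring but loses the hydrogen-bond donor of compound 1, so a weakening beyond the scatter is expected, yet well short of an at least 31-fold higher number from compound 1 to compound 2 (1.49 log units; beyond the scatter). Compound 4 is estimated at 20000 nM (range 6000 nM to 80000 nM), an expected step of a 4.2-fold higher number from compound 1 to compound 4 (0.62 log units; beyond the scatter).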

Compound 4, concentration for 50% growth inhibition: > 75000 nM
Compound 4: a limit, no number; the forecaster's own chance of this, stated with the estimate: 15%; middle value at least 3.7-fold (0.57 log units) from the limit.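

In this assay compound 4 gives a limit, not a number: the limit of > 75000 nM in this assay, at which 1 of the 4 values shown sits. On the triple-bonded carbon, a carbon-only ring is therefore not enough to keep a measured number: methoxy in place of amino gives an at least 6.4-fold higher number from compound 3 to compound 4 (0.81 log units; beyond the scatter), and 3-methoxyphenyl in place of 4-aminophenyl gives an at least 15-fold higher number from compound 1 to compound 4 (1.19 log units; beyond the scatter). The step between compound 2 and compound 4 cannot be read, as both values are limits.

Whether the amino group's hydrogen-bond donor accounts for the loss stays open. A 3-hydroxyphenyl or 3-(methylamino)phenyl group on the same carbon would bear on this.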